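Swapping sulfur for selenium in a pseudothiourea-type linker

A few compounds are considered here, and "the series" means these few. Any claim that something is new, unique, unknown or untested is made for them only; others in the source may bear on it.

Of the compounds shown here, three have been tested in a functional assay on K562 cells (Homo sapiens) for cytotoxicity, read by MTT assay, with a stated time of 72 h; a higher number here means a weaker inhibitor of growth, a lower number a stronger inhibitor of growth. Compound 1 `CS/C(=N\C(=O)c1sccc1Cl)NC(=O)c1sccc1Cl` gives 78900 nM in this assay. Compound 2 `CS/C(=N\C(=O)c1csc([N+](=O)[O-])c1)NC(=O)c1csc([N+](=O)[O-])c1` gives 98700 nM in this assay. Compound 3 `C[Se]/C(=N\C(=O)c1ccno1)NC(=O)c1ccno1` gives 45600 nM in this assay. Among these three numbers, compound 2 has the largest; compound 1 sits so close to it that the two cannot be told apart within the usual scatter, whereas compound 3 shows a number clearly smaller than that of compound 2, beyond the scatter.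

The unmeasured compound 4 `C[Se]/C(=N\C(=O)c1csc([N+](=O)[O-])c1)NC(=O)c1csc([N+](=O)[O-])c1` keeps the whole of compound 2 except at one place. The change is a group of 2 heavy atoms (1 carbon, 1 selenium; no ring) in place of a group of 2 heavy atoms (1 carbon, 1 sulfur; no ring), on a carbon with a double bond to nitrogen. Within the data shown here, compound 3 is the only measured compound that carries the selenium-bearing group, but its ring parts differ from those of compound 2, so no direct step for this exchange is available.

The step from compound 2 to compound 4 in this assay is expected to be small, most likely toward a somewhat smaller number, and possibly not beyond the scatter: a 1.4-fold lower number from compound 2 to compound 4 (0.15 log units; within the scatter). On that basis, compound 4 is estimated to give about 70000 nM in this assay, with a plausible range from 30000 nM to 160000 nM.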

Compound 4, concentration for total growth inhibition: > 100000 nM
Compound 4 gave a limit, no number; the forecaster's own chance of this, stated with the estimate: 5%; middle value at least 1.4-fold (0.15 log units) from the limit.
By their numbers in this assay, from the lowest: compounds 3, 1 and 2 (each within the scatter of the next, the first and the last beyond it). At a limit, above all of these: compound 4.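

In this assay compound 4 gives > 100000 nM, which is a limit of the assay and not a number. Among these compounds, this pair offers the first direct look at selenium in place of sulfur on a carbon with a double bond to nitrogen, and it gives an at least 1.0-fold higher number from compound 2 to compound 4 (0.00 log units; that floor lies within the scatter), so the exchange shows no gain in growth inhibition here, although the floor of that step lies within the scatter. Whatever sets compound 3 apart, this pair gives no sign that the selenium-bearing group alone accounts for it, and the true size of the step stays unknown, as the reading stops at the edge of the assay: the limit of > 100000 nM in this assay, at which 1 of the 4 values shown sits.

The compounds shown leave open whether the same exchange would behave alike with other ring parts, since neither the ring parts of compound 1 nor those of compound 3 appear here on both sides of the sulfur-to-selenium exchange. Also open, as far as these compounds go, is how a methoxy group, with oxygen in this place, or a longer chain such as ethyl on the selenium would read out.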